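A few compounds are considered here, and "the series" means these few. Any claim that something is new, unique, unknown or untested is made for them only; others in the source may bear on it.

Compound 1 `O=C1OCCc2c(CO)cccc21`: > 3800000 nM
Compound 2 `CCOCC(=O)OCc1cccc2c1CCOC2=O`: > 3680000 nM
Compound 3 `O=C(O)c1ccccc1C(=O)OCc1cccc2c1CCOC2=O`: 130000 nM

All three were read in an ADME assay on HepG2 2.2.15 cells (Homo sapiens) for cytotoxicity, read by MTT assay, with a stated time of 72 h; a higher number here means that more compound is tolerated, a lower number that less compound is tolerated. Compound 1 gives no number, only a limit: the limit of > 3800000 nM in this assay, at which 1 of the 3 values shown sits. Compound 2 also gives only a limit: the limit of > 3680000 nM in this assay, at which 1 of the 3 values shown sits. Compound 3 alone carries a number, and it lies well under both limits.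

Compound 4 `NC(=O)c1cccc2c1CCOC2=O` is the next to be read, and its change from the core of compound 1 is carbamoyl in place of hydroxymethyl on an aromatic carbon. In words, this is carbamoyl in place of hydroxymethyl on an aromatic carbon.

For the measured compounds named here, the only measured step is a step that the two limits leave unreadable from compound 1 to compound 2, so it offers no size to carry over, and no measured step replaces the hydroxymethyl. No step beyond the scatter can be argued from these data, and another limit reading is the likeliest outcome in this assay. The expectation rests on compound 1, whose limit is > 3800000 nM. If a number appears, a modest downward move is expected. The estimated step is an at least 1.5-fold lower number from compound 1 to compound 4 (0.18 log units; that floor lies within the scatter). For compound 4 the expected value is 2500000 nM, with an estimated range of 400000 nM to 5000000 nM.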

Compound 4, half-maximal cytotoxic concentration: > 3290000 nM
Compound 4 ended at the assay's limit; the forecaster's own chance of this, stated with the estimate: 65%; middle value at least 1.3-fold (0.11 log units) away from the limit.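

For the compounds shown here, compound 4 gives only the limit > 3290000 nM in this assay and compound 1 also gives only a limit, so no step from compound 1 to compound 4 can be read. The compounds shown leave open whether carbamoyl and hydroxymethyl on the aromatic carbon differ at all in this read-out.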